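Swapping a Bromophenyl for Thiophene on a Shared Core

This account rests on a few compounds, and the source may have more. Where it says the series, first, only, none or still open, it means among the compounds named here.

Measured so far in a functional assay on A549 cells (Homo sapiens) for inhibition, read by sulforhodamine B assay, with a stated time of 48 h, tested at 10 uM; a lower number here means less inhibition, a higher number more inhibition at the concentration tested (going by the name of the read-out):
compound 1 `Brc1cn2ccnc2c(-c2ccc3ncn(C4CCCCC4)c3c2)n1` gives 9.36%
compound 2 `COc1ccc(-c2cn3ccnc3c(-c3ccc4ncn(C5CCCCC5)c4c3)n2)cc1` gives 68.6%
compound 3 `Brc1ccc(-c2cn3ccnc3c(-c3ccc4ncn(C5CCCCC5)c4c3)n2)cc1` gives 15.3%

Compound 3 stands second highest of the three numbers. The step of a number 5.9 percentage points higher from compound 1 to compound 3 (within the scatter) lies within the scatter, while the step of a number 53.3 percentage points lower from compound 2 to compound 3 (beyond the scatter) is large and beyond it. Compound 4 `c1csc(-c2cn3ccnc3c(-c3ccc4ncn(C5CCCCC5)c4c3)n2)c1` differs from compound 3 by thiophen-2-yl in place of 4-bromophenyl on an aromatic carbon. Within the data shown here, no measured step exchanges one aromatic ring for another. The steps of a number 5.9 percentage points higher from compound 1 to compound 3 (within the scatter) and a number 53.3 percentage points lower from compound 2 to compound 3 (beyond the scatter) show that adding a ring at this position changed the number little, whereas exchanging methoxy for bromo on that ring shifted it far. Among the measured compounds shown here, with no close precedent, compound 4 is expected to stay near compound 3, the expected step being a number 6.7 percentage points higher from compound 3 to compound 4 (within the scatter). The estimate for compound 4 is 22%, with a range from 5% to 55%.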

Compound 4, a percentage reported as inhibition, at one concentration (the size of the read-out at that concentration, not a potency): 5.33%
Estimate against measurement, compound 4: 16.7 percentage points above; measured number inside the range.
By their numbers in this assay, from the lowest: compounds 4, 1 and 3 (each within the scatter of the next); then compound 2.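

In this assay, thiophen-2-yl in place of 4-bromophenyl gives a number 10 percentage points lower from compound 3 to compound 4 (within the scatter) and thiophen-2-yl in place of bromo gives a number 4 percentage points lower from compound 1 to compound 4 (within the scatter), so a second kind of aromatic ring at this position also leaves the number within the scatter of the bromo compound. Thiophen-2-yl in place of 4-methoxyphenyl gives a number 63.3 percentage points lower from compound 2 to compound 4 (beyond the scatter) and shows that an aromatic ring alone does not carry the high number among these compounds. No measurement here explains this difference.

From the compounds shown here alone, it remains open whether a methoxy group on the thiophene ring would restore the high number, and whether an amine on the phenyl ring would match methoxy.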